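The source may report more compounds than this note shows. Statements on the series, on what has been measured and on what is new or still open speak of the compounds shown alone.

Compound 3, `COc1cc(C(=O)N2CCC(O)C(C)C2)cc2nc(NCc3cccc(Cl)c3)oc12`, gives 25 nM in an assay on isolated protein for inhibition of thyroid hormone receptor beta (Homo sapiens), read by fluorescence, with a stated time of 30 min (on this read-out lower numbers stand for stronger inhibition and higher numbers for weaker inhibition), the lowest of the three numbers recorded. Compound 1, `COc1cc(C(=O)N2CCCC2(C)C)cc2nc(NCc3cccc(Cl)c3)oc12`, gives 47 nM in this assay, and the step of a 1.9-fold lower number from compound 1 to compound 3 (0.27 log units; within the scatter) lies within the scatter, so the two cannot be ranked. Compound 2, `COc1cc(C(=O)N2CCC(O)CC2)cc2nc(NCc3cccc(Cl)c3)oc12`, gives 352 nM in this assay; the step of a 14-fold lower number from compound 2 to compound 3 (1.15 log units; beyond the scatter) is large, and the step of a 7.5-fold higher number from compound 1 to compound 2 (0.87 log units; beyond the scatter) is modest.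

Compound 4, `CCC1CC(O)C(C)CN1C(=O)c1cc(OC)c2oc(NCc3cccc(Cl)c3)nc2c1`, differs from compound 3 by ethyl in place of hydrogen on a saturated ring carbon, on a six-membered non-aromatic ring with one nitrogen, next to the ring nitrogen and two ring bonds from the ring atom that bears a hydroxy group. Among the compounds with values here, the only measured step that adds a small alkyl group to this same ring is a 14-fold lower number from compound 2 to compound 3 (1.15 log units; beyond the scatter), which was large and lowered the number; no step tests an alkyl group at the position now altered, and no step tests an ethyl group at all. Compound 4 is therefore expected to remain close to compound 3, with the step of a 1.2-fold higher number from compound 3 to compound 4 (0.08 log units; within the scatter) expected to stay within the scatter. Compound 4 is estimated at 30 nM in this assay, within a range from 10 nM to 100 nM.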

Compound 4, half-maximal inhibitory concentration: 13 nM
Estimate against measurement, compound 4: 2.3-fold (0.36 log units) above; the measured number falls inside the stated range.
By their numbers in this assay, from the lowest: compounds 4, 3 and 1 (each within the scatter of the next, the first and the last beyond it); then compound 2.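

In this assay, ethyl on the saturated ring carbon next to the ring nitrogen leaves the number where it cannot be told from that of compound 3, as a 1.9-fold lower number from compound 3 to compound 4 (0.28 log units; within the scatter) shows, so this position accepts ethyl with the methyl group already on the ring. The 2-ethyl-4-hydroxy-5-methylpiperidin-1-yl group stands well clear of the 4-hydroxypiperidin-1-yl group, with a 27-fold lower number from compound 2 to compound 4 (1.43 log units; beyond the scatter), and it also separates from the 2,2-dimethylpyrrolidin-1-yl group, with a 3.6-fold lower number from compound 1 to compound 4 (0.56 log units; beyond the scatter), whereas a 1.9-fold lower number from compound 1 to compound 3 (0.27 log units; within the scatter) did not separate compound 3 from compound 1. Nothing available accounts for how the ethyl group acts at this position.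

Still open, going by these compounds, is how a longer chain such as propyl, or a hydroxymethyl or aminomethyl group, would read at this same ring carbon in this assay. Also open, on these data alone, is what ethyl would do at this position on the 4-hydroxypiperidin-1-yl ring without the methyl group, which would show whether the two alkyl groups depend on each other.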